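The source may report more compounds than this note shows. Statements on the series, on what has been measured and on what is new or still open speak of the compounds shown alone.

Measured in an ADME assay on HEK293 cells (Homo sapiens) for cytotoxicity, read by MTT assay, with a stated time of 48 h; on this read-out lower numbers stand for stronger inhibition and higher numbers for weaker inhibition:
compound 1 `O=C1/C(=C\c2ccc(O)cc2)S/C(=N/c2ccccc2)N1Cc1ccncc1`: 142000 nM
compound 2 `O=C1/C(=C\c2ccc(O)c(O)c2)S/C(=N/c2ccccc2)N1Cc1ccncc1`: 230000 nM
compound 3 `COc1cc(/C=C2/S/C(=N/c3ccccc3)N(Cc3ccncc3)C2=O)ccc1O`: 67400 nM

Compound 3 has the lowest number of the three, and it alone carries a methoxy group. Compound 4 `O=C1/C(=C\c2cccc(O)c2)S/C(=N/c2ccccc2)N1Cc1ccncc1` has 3-hydroxyphenyl in place of 4-hydroxy-3-methoxyphenyl, on a double-bonded chain carbon bound to a double-bonded ring carbon (3-hydroxyphenyl in place of 4-hydroxy-3-methoxyphenyl on a double-bonded chain carbon bound to a double-bonded ring carbon). For the measured compounds named here, two measured steps bear on this change. Adding the methoxy gave a 2.1-fold lower number from compound 1 to compound 3 (0.32 log units; beyond the scatter), and adding methyl on the oxygen gave a 3.4-fold lower number from compound 2 to compound 3 (0.53 log units; beyond the scatter). Going by the values given here, no measured compound carries 3-hydroxyphenyl, so that group itself is untested. Since compound 4 has no methoxy, the expected step is modest and upward, a 2.2-fold higher number from compound 3 to compound 4 (0.35 log units; beyond the scatter). For compound 4 the estimated value is 150000 nM, with an expected range from 70000 nM to 320000 nM.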

Compound 4, half-maximal inhibitory concentration: 150000 nM
For compound 4 middle estimate and measured number coincide at the digits printed, and the stated range covers the measured number.
By their numbers in this assay, from the lowest: compound 3; then compounds 1, 4 and 2 (each within the scatter of the next).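

Replacing 4-hydroxy-3-methoxyphenyl with 3-hydroxyphenyl gives (a 2.2-fold higher number from compound 3 to compound 4 (0.35 log units; beyond the scatter)), so a single hydroxy on this ring does not match the lower number of compound 3. The hydroxy can be on either ring carbon without a difference beyond the scatter (a 1.1-fold higher number from compound 1 to compound 4 (0.02 log units; within the scatter)), and removing one hydroxy from the pair in compound 2 also stays within it (a 1.5-fold lower number from compound 2 to compound 4 (0.19 log units; within the scatter)), leaving compound 3 alone apart from the other three. No measurement here explains this pattern. As far as these compounds go, whether a 3-methoxyphenyl group without any hydroxy would keep the lower number remains open, as does the effect of an amine or an ethoxy group on this ring.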